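This account rests on a few compounds, and the source may have more. Where it says the series, first, only, none or still open, it means among the compounds named here.

Measured compounds:
compound 1, `CC(C)CC(=O)NC(C(=O)N[C@@H](CC(C)C)[C@@H](O)CC(C)C(=O)NC(C)C(=O)NC(=O)C(C)C)C(C)C`: 3 nM
compound 2, `CC(C)CCNC(=O)C(C)NC(=O)CCC(=O)[C@H](CC(C)C)NC(=O)C(NC(=O)CC(C)C)C(C)C`: 2140 nM
compound 3, `CC(C)CCNC(=O)C(C)NC(=O)CC(=O)C(CC(C)C)NC(=O)C(NC(=O)CC(C)C)C(C)C`: 56 nM

In an assay on isolated protein for inhibition of Pepsin A (Sus scrofa) (a higher number here means a weaker inhibitor, a lower number a stronger inhibitor), compound 2 gives 2140 nM, the highest of the three numbers and therefore the weakest inhibitor of the set. Its nearest neighbour is compound 3, which in this assay gives 56 nM, and the furthest is compound 1, which gives 3 nM; both gaps lie beyond the scatter of repeated measurements.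

The next compound, compound 4, `CC(C)CCNC(=O)C(C)NC(=O)C(CC(=O)[C@H](CC(C)C)NC(=O)C(NC(=O)CC(C)C)C(C)C)Cc1ccccc1`, is derived from compound 2 by a single change: benzyl in place of hydrogen on a saturated chain carbon bound to a carbonyl carbon and a saturated chain carbon. Among the compounds with values here, no pair of measured compounds shows this change, so its effect can only be anticipated. Since compound 2 starts from the weakest position, there is room for a lower number, and a substituent of this size at that chain carbon is more likely to lower the inhibition constant than to raise it. The step is expected to be a 14-fold lower number from compound 2 to compound 4 (1.15 log units; beyond the scatter), a decrease beyond the scatter. Compound 4 is accordingly estimated at 150 nM, within a range of 30 nM to 800 nM.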

Compound 4, inhibition constant: 72 nM
Estimate against measurement, compound 4: 2.1-fold (0.32 log units) above, and the stated range covers the measured number.
By their numbers in this assay, from the lowest: compound 1; then compounds 3 and 4 (each within the scatter of the next); then compound 2.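

In this assay, within the data shown here, benzyl in place of hydrogen on this saturated chain carbon, bound to a carbonyl carbon and a saturated chain carbon, gives a 30-fold lower number from compound 2 to compound 4 (1.47 log units; beyond the scatter), a large step and the first reading of any change at this position. It shows that the position accepts a group of this size and that this single change takes compound 2 away from the weak end of the set. Nothing available bears on why the number falls.

Going by these compounds, what a methyl, a cyclohexylmethyl or a 4-hydroxybenzyl group would do on the same carbon stays open, and with it the question of whether the six-membered aromatic ring is needed at all. Also open, on these data alone, is whether a carboxylic acid or an amine would be accepted there.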